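Replacing 2,3-dimethoxyphenyl with 2,3,4-trifluorophenyl

This account rests on a few compounds, and the source may have more. Where it says the series, first, only, none or still open, it means among the compounds named here.

In a functional assay on CCRF-CEM cells (Homo sapiens) for antiproliferative activity, with a stated time of 72 h (a higher number here means a weaker inhibitor, a lower number a stronger inhibitor), compound 1 (`OC[C@H]1O[C@@H](n2cnc3c(NCc4cccc(F)c4)ncnc32)[C@H](O)[C@@H]1O`) gives 4000 nM and compound 2 (`COc1ccccc1CNc1ncnc2c1ncn2[C@@H]1O[C@H](CO)[C@@H](O)[C@H]1O`) gives 3200 nM. Compound 3 (`COc1cccc(CNc2ncnc3c2ncn3[C@@H]2O[C@H](CO)[C@@H](O)[C@H]2O)c1OC`) gives only a limit, > 166000 nM. Compound 4 (`OC[C@H]1O[C@@H](n2cnc3c(NCc4ccc(F)c(F)c4F)ncnc32)[C@H](O)[C@@H]1O`) carries 2,3,4-trifluorophenyl in place of 2,3-dimethoxyphenyl (2,3,4-trifluorophenyl in place of 2,3-dimethoxyphenyl on a saturated chain carbon bound to a nitrogen on an aromatic ring). Among the measured compounds shown here, three measured steps bear on this change: a 1.3-fold lower number from compound 1 to compound 2 (0.10 log units; within the scatter), then an at least 41-fold higher number from compound 1 to compound 3 (1.61 log units; beyond the scatter) and an at least 51-fold higher number from compound 2 to compound 3 (1.71 log units; beyond the scatter), the last two being large. Compound 4 has fluorine on its ring, as does compound 1 at 4000 nM, and it lacks the methoxy added in an at least 51-fold higher number from compound 2 to compound 3 (1.71 log units; beyond the scatter). A large step towards a lower number, meaning a stronger inhibitor, is therefore expected: an at least 33-fold lower number from compound 3 to compound 4 (1.52 log units; beyond the scatter). Compound 4 is estimated at 5000 nM, with an expected range of 1200 nM to 40000 nM.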

Compound 4, half-maximal inhibitory concentration: 58200 nM
For compound 4 the middle estimate is 12-fold (1.07 log units) below the measured one, outside the stated range (above it).
By their numbers in this assay, from the lowest: compounds 2 and 1 (each within the scatter of the next); then compound 4. At a limit, above all of these: compound 3.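

In this assay, fluorine on the ring at this saturated chain carbon does not by itself keep the level of the singly substituted rings: there is a 15-fold higher number from compound 1 to compound 4 (1.16 log units; beyond the scatter), and an 18-fold higher number from compound 2 to compound 4 (1.26 log units; beyond the scatter). Replacing 2,3-dimethoxyphenyl with 2,3,4-trifluorophenyl gives an at least 2.8-fold lower number from compound 3 to compound 4 (0.45 log units; beyond the scatter), so the change recovers only part of what the second methoxy cost. Compound 3 is held at a limit: the limit of > 166000 nM in this assay, at which 1 of the 4 values shown sits.

Going by these compounds, whether the loss follows the number of ring substituents or the particular groups stays open. So does how a ring carrying an amine or a carboxylic acid would behave here.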